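This account rests on a few compounds, and the source may have more. Where it says the series, first, only, none or still open, it means among the compounds named here.

Values in a functional assay on P388 cells (Mus musculus) for antiproliferative activity, with a stated time of 72 h (a higher number here means that more compound is needed for the effect, a lower number that less compound is needed), so far

compound 1 `Cc1cn([C@@H]2O[C@H](CO)[C@@H](CO)[C@@H]2O)c(=O)[nH]c1=O` gives > 100 uM
compound 2 `Cc1cn([C@H]2C[C@H](CN)[C@@H](CO)O2)c(=O)[nH]c1=O` gives > 100 uM

For compound 2, > 100 uM is a limit of the assay and not a number. Compound 2 stands, with compound 1, at the limit of > 100 uM in this assay, at which 2 of the 2 values shown sit, and so offers no exact starting point.

Compound 3 `Cc1cn([C@H]2C[C@H](CO)[C@@H](CO)O2)c(=O)[nH]c1=O` differs from compound 2 in one place (hydroxy in place of amino on a saturated chain carbon bound to a saturated ring carbon), with hydroxy in place of amino on a saturated chain carbon bound to a saturated ring carbon. Going by the values given here, no measured pair shows a change of this kind, so its size remains open. Compound 2 gives > 100 uM as a limit, and from it no step beyond the usual scatter is expected in this assay in either direction. The estimate means a number no higher from compound 2 to compound 3 (the limit leaves the size open) as the expected change. Compound 3 is expected near 100 uM with an estimated range from 50 uM to 200 uM. A limit rather than an exact number is also expected for compound 3.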

Compound 3, concentration for half-maximal effect: 5 uM
Beside the measured number, compound 3's estimate is 20-fold (1.30 log units) above it; measured number outside the range, below it.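

In this assay, the aminomethyl to hydroxymethyl change turns a compound with no exact value into one with a measurable effect, giving an at least 20-fold lower number from compound 2 to compound 3 (1.30 log units; beyond the scatter). A second place on the core also matters: hydrogen in place of hydroxy on a saturated ring carbon gives an at least 20-fold lower number from compound 1 to compound 3 (1.30 log units; beyond the scatter), so among these three compounds, only the one with both hydroxymethyl and that ring hydrogen reaches an exact number. Both steps start from a limit of the assay rather than a number, so each gives only a minimum size: the limit of > 100 uM in this assay, at which 2 of the 3 values shown sit.

The compounds shown leave open whether the hydroxy group itself is needed on this chain carbon, or whether a methyl ether or a fluorine there would serve as well. They also leave open what a longer chain, such as hydroxyethyl, would do at this position.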